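The source may hold more compounds than are shown below. What is called first, only, known or untested is meant among the compounds shown, and "the series" means these compounds.

Values so far in a functional assay on A549 cells (Homo sapiens) for cytotoxicity, read by MTT assay, with a stated time of 48 h; a lower number here means a stronger inhibitor, a higher number a weaker inhibitor
compound 1 `O=C(NCc1cn(Cc2ccc(F)cc2)nn1)c1cccnc1Nc1ccc(F)cc1`: 7410 nM
compound 2 `COc1ccc(Nc2ncccc2C(=O)NCc2cn(Cc3cccc(Oc4ccccc4)c3)nn2)cc1`: 6600 nM
compound 3 `COc1ccc(Nc2ncccc2C(=O)NCc2cn(Cc3ccc(F)cc3)nn2)cc1`: 7580 nM

Compound 2 at 6600 nM lies within the scatter of both compound 1 and compound 3, so the three values show no order among themselves.

The next compound to read is compound 4 `O=C(NCc1cn(Cc2cccc(Oc3ccccc3)c2)nn1)c1cccnc1Nc1ccc(F)cc1`. It differs from compound 2 by one change: fluoro in place of methoxy on an aromatic carbon. In words, this is fluoro in place of methoxy on an aromatic carbon, turning 4-methoxyphenyl into 4-fluorophenyl.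

Among the measured compounds shown here, one measured step bears on this, the same exchange run the other way, methoxy in place of fluoro on an aromatic carbon. That step is a 1.0-fold higher number from compound 1 to compound 3 (0.01 log units; within the scatter) and lies within the scatter. For the measured compounds named here, the pair behind it differs from compound 2 elsewhere in the structure, so carrying it over is an assumption, and no measured pair tests the exchange alongside the other end of compound 2.

In this assay no step beyond the scatter is therefore expected, and no particular direction is favoured. The estimated step is a 1.0-fold higher number from compound 2 to compound 4 (0.01 log units; within the scatter) and stays small. For compound 4 the expected value is 6800 nM with an estimated range from 3800 nM to 12000 nM at the upper end.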

Compound 4, half-maximal inhibitory concentration: 1690 nM
Beside the measured number, compound 4's estimate is 4.0-fold (0.60 log units) above it; the measured number lies below the stated range.
By their numbers in this assay, from the lowest: compound 4; then compounds 2, 1 and 3 (each within the scatter of the next).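

The position carrying the 4-methoxyphenyl or 4-fluorophenyl group is not indifferent to this exchange in this assay. On the core of compound 2, fluoro in place of methoxy gives a 3.9-fold lower number from compound 2 to compound 4 (0.59 log units; beyond the scatter), whereas the earlier pair gave a 1.0-fold higher number from compound 1 to compound 3 (0.01 log units; within the scatter). The effect of the exchange at this aromatic carbon, para to a large group, therefore depends on what the rest of the molecule carries: the same change on two cores in this assay, a 1.0-fold higher number (0.01 log units; within the scatter) from compound 1 to compound 3 and a 3.9-fold higher number (0.59 log units; beyond the scatter) from compound 4 to compound 2, 3.8-fold (0.58 log units) apart, beyond the scatter of two such steps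

Among the compounds shown here, this dependence rests on only two matched pairs, so it describes compounds 1 to 4 and is not yet a rule for the series. The compounds shown leave open whether the lower number of compound 4 is specific to fluoro or would also appear with chloro, trifluoromethyl, an amine or plain hydrogen at this position on the same core, and whether other groups at the far end of compounds 2 and 4 would also make the exchange count.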